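Replacing the nitrogen substituent of compound 2

The source may hold more compounds than are shown below. What is called first, only, known or untested is meant among the compounds shown, and "the series" means these compounds.

Within the data shown here, in a functional assay on K562 cells (Homo sapiens) for cytotoxicity, read by trypan blue exclusion, with a stated time of 96 h (a lower number here means a stronger inhibitor, a higher number a weaker inhibitor), compound 1 `COC(=O)CCNc1cc(CS(=O)(=O)/C=C/c2c(OC)cc(OC)cc2OC)ccc1OC` gives 1000 nM and compound 2 `COc1cc(OC)c(/C=C/S(=O)(=O)Cc2ccc(OC)c(NC(C)(C)C(=O)O)c2)c(OC)c1` gives 7.5 nM, the lower of the two numbers so far. Compound 3 `COc1cc(OC)c(/C=C/S(=O)(=O)Cc2ccc(OC)c(NC(C(=O)O)c3ccc(Br)cc3)c2)c(OC)c1` differs from compound 2 as follows: (4-bromophenyl)(carboxy)methyl in place of 1-carboxy-1-methylethyl on a nitrogen on an aromatic ring. Among the measured compounds shown here, the one measured step on this nitrogen, a 130-fold lower number from compound 1 to compound 2 (2.12 log units; beyond the scatter), is large, but it involves 2-(methoxycarbonyl)ethyl, and compound 3 retains a carboxy-bearing substituent. For the measured compounds named here, no measured compound carries an aromatic ring in this substituent, so only a moderate rise, with wide uncertainty, is expected: a 3.3-fold higher number from compound 2 to compound 3 (0.52 log units; beyond the scatter). The estimated value for compound 3 is 25 nM, with an expected range of 5 nM to 200 nM.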

Compound 3, half-maximal inhibitory concentration: 200 nM
For compound 3 the middle estimate is 8.0-fold (0.90 log units) below the measured one; the measured number falls inside the stated range.
By their numbers in this assay, from the lowest: compound 2; then compound 3; then compound 1.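

In this assay, a carboxy group on the nitrogen substituent does not by itself keep the number low: with the (4-bromophenyl)(carboxy)methyl group there is a 27-fold higher number from compound 2 to compound 3 (1.43 log units; beyond the scatter). This group still fares better than 2-(methoxycarbonyl)ethyl, with a 5.0-fold lower number from compound 1 to compound 3 (0.70 log units; beyond the scatter), so the three substituents span a wide range at this nitrogen. No evidence on the cause of either step is available.

The compounds shown do not separate the contribution of the bromine from that of the aromatic ring. Also open, going by these compounds, is how a carboxymethyl, a 2-carboxyethyl or an unsubstituted (phenyl)(carboxy)methyl group would read here.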